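The source may report more compounds than this note shows. Statements on the series, on what has been measured and on what is new or still open speak of the compounds shown alone.

Compound 1 `O=C(NCCCCc1ccccc1)n1c(=O)oc2cc([N+](=O)[O-])ccc21`, compound 2 `O=C(NCCCCc1ccccc1)n1c(=O)oc2cc(F)ccc21` and compound 3 `O=C(NCCCCc1ccc(F)cc1)n1c(=O)oc2ccccc21` share a core and differ in where a single substituent sits. In an assay on HEK293 cells for inhibition of acid ceramidase (Homo sapiens), with a stated time of 10 min (on this read-out lower numbers stand for stronger inhibition and higher numbers for weaker inhibition), compound 1 gives 3 nM, compound 2 gives 31 nM and compound 3 gives 75 nM, the highest of the three. The difference between the cores of compound 2 and compound 3 is not broken down here; the two have the same atoms joined differently. Within the core ring, the change nitro in place of fluoro on an aromatic carbon produced a 10-fold lower number from compound 2 to compound 1 (1.01 log units; beyond the scatter).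

Compound 4 `O=C(NCCCCc1ccc([N+](=O)[O-])cc1)n1c(=O)oc2ccccc21` is not yet measured. Among the measured compounds shown here, it is reached from compound 3 by the change (nitro in place of fluoro on an aromatic carbon), which is the same kind of change as the one from compound 2 to compound 1, but not the same: there the ring was part of a fused or bridged system of two rings, with the position meta to a fused ring and para to a fused ring, whereas here the ring is of carbon only, not fused, and the position is para to a large group. Because the earlier step of a 10-fold lower number from compound 2 to compound 1 (1.01 log units; beyond the scatter) was made at a different place, its size is expected to carry over only in part to this assay. Compound 4 is therefore estimated at 30 nM, within 8 nM to 100 nM, which would mean an expected step of a 2.5-fold lower number from compound 3 to compound 4 (0.40 log units; beyond the scatter).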

Compound 4, half-maximal inhibitory concentration: 312 nM
Beside the measured number, compound 4's estimate is 10-fold (1.02 log units) below it; the measured number lies above the stated range.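

The same exchange of fluoro for nitro, made in this assay on the six-membered aromatic ring of carbon only and para to a large group, gave a 4.2-fold higher number from compound 3 to compound 4 (0.62 log units; beyond the scatter), so it did not keep even its direction when carried from the earlier place, as the two steps set side by side show: the same change on two cores in this assay, a 10-fold lower number (1.01 log units; beyond the scatter) from compound 2 to compound 1 and a 4.2-fold higher number (0.62 log units; beyond the scatter) from compound 3 to compound 4, 43-fold (1.63 log units) apart, beyond the scatter of two such steps Within these four compounds, then, a step measured on one ring gives no safe guide to either the direction or the size of the same exchange on the other ring. This does not show what produces the gap, and it does not amount to a rule: there is a single pair at each place, and the two pairs differ in both the ring and the position of the change, so the contribution of each cannot be separated.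

The compounds shown leave open whether another group at these same two places, such as an amine, a methoxy or a carboxylic acid, would follow compound 1 or compound 4. They also leave open whether either step would hold with a longer chain in place of the four-carbon one shared by all four compounds.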